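The source may report more compounds than this note shows. Statements on the series, on what has been measured and on what is new or still open speak of the compounds shown alone.

In a functional assay on HeLa cells (Homo sapiens) for antiproliferative activity, read by spectrophotometry, with a stated time of 2 days (on this read-out lower numbers stand for stronger inhibition of growth and higher numbers for weaker inhibition of growth), compound 1 (`COc1ccc(Nc2ncc(C(F)(F)F)c(N3Cc4cccc(N(C)S(C)(=O)=O)c4C3)n2)cc1C(F)(F)F`) gives 14000 nM. Compound 2 (`Cc1ccc(Nc2ncc(C(F)(F)F)c(N3Cc4cccc(N(C)S(C)(=O)=O)c4C3)n2)cc1C`) reads > 30000 nM, which is a limit. Compound 3 (`Cc1cc(C)cc(Nc2ncc(C(F)(F)F)c(N3Cc4cccc(N(C)S(C)(=O)=O)c4C3)n2)c1`) reads > 30000 nM, also a limit, and so stands at the limit of > 30000 nM in this assay, at which 2 of the 3 values shown sit. Compound 4 (`CN(c1cccc2c1CN(c1nc(Nc3ccc(Cl)c(C(F)(F)F)c3)ncc1C(F)(F)F)C2)S(C)(=O)=O`) differs from it by 4-chloro-3-(trifluoromethyl)phenyl in place of 3,5-dimethylphenyl on a nitrogen on an aromatic ring, with 4-chloro-3-(trifluoromethyl)phenyl in place of 3,5-dimethylphenyl on a nitrogen on an aromatic ring. Going by the values given here, two measured steps bear on this change, an at least 2.1-fold higher number from compound 1 to compound 2 (0.33 log units; beyond the scatter) and an at least 2.1-fold higher number from compound 1 to compound 3 (0.33 log units; beyond the scatter), both at least modest and beyond the scatter. Each loses a trifluoromethyl-bearing phenyl, which compound 4 regains, so a modest move toward stronger inhibition is expected. The estimated step is an at least 2.5-fold lower number from compound 3 to compound 4 (0.39 log units; beyond the scatter). For compound 4 the expected value is 12000 nM, within an estimated range of 4000 nM to 30000 nM.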

Compound 4, concentration for 50% growth inhibition: 11100 nM
For compound 4 the middle estimate is 1.1-fold (0.03 log units) above the measured one; measured number inside the range.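

In this assay, 4-chloro-3-(trifluoromethyl)phenyl in place of either dimethylphenyl gives a measured number rather than a limit, with an at least 2.7-fold lower number from compound 3 to compound 4 (0.43 log units; beyond the scatter) and an at least 2.7-fold lower number from compound 2 to compound 4 (0.43 log units; beyond the scatter). Chloro in place of methoxy gives a 1.3-fold lower number from compound 1 to compound 4 (0.10 log units; within the scatter), so the two trifluoromethyl-bearing compounds cannot be told apart here. Compound 2 and compound 3, which carry two methyl groups instead, both stay at a limit of the assay: the limit of > 30000 nM in this assay, at which 2 of the 4 values shown sit.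

As far as these compounds go, it remains open whether trifluoromethyl alone accounts for the gap to the dimethylphenyl compounds. Also open, from the compounds shown here alone, is how an amine or a carboxylic acid on this phenyl ring would read.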